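This account rests on a few compounds, and the source may have more. Where it says the series, first, only, none or still open, it means among the compounds named here.

Working notes on the series. Compound 1 `O=C(O)c1ccc(C(=O)c2ccc(C(=O)c3ccc(C(=O)O)cc3)cc2)cc1`, compound 2 `O=C(O)c1ccc(C(=O)c2ccc(C(=O)c3ccc(O)cc3)cc2)cc1` and compound 3 `O=C(O)c1ccc(C(=O)c2ccc(C(=O)c3ccc(Cl)cc3)cc2)cc1` share one core and differ at a single aromatic carbon. In an assay on CHO cells for inhibition of 3-oxo-5-alpha-steroid 4-dehydrogenase 2 (Homo sapiens) (on this read-out lower numbers stand for stronger inhibition and higher numbers for weaker inhibition), compound 1 gives 1000 nM, compound 2 gives 22 nM and compound 3 gives 35 nM. Going by the values given here, compound 2 gives the lowest of the three numbers, but only one of its two steps lies beyond the scatter, a 45-fold lower number from compound 1 to compound 2 (1.66 log units; beyond the scatter); the other, a 1.6-fold higher number from compound 2 to compound 3 (0.20 log units; within the scatter), does not. Compound 4 `O=C(O)c1ccc(C(=O)c2ccc(C(=O)c3ccc(C(F)(F)F)cc3)cc2)cc1` carries trifluoromethyl in place of hydroxy on an aromatic carbon, on an aromatic carbon of a six-membered aromatic ring of carbon only, para to a large group. The large steps seen, a 45-fold lower number from compound 1 to compound 2 (1.66 log units; beyond the scatter) and a 29-fold lower number from compound 1 to compound 3 (1.46 log units; beyond the scatter), both came with the loss of carboxy, which compound 4 also lacks, whereas the exchange of hydroxy for chloro, a 1.6-fold higher number from compound 2 to compound 3 (0.20 log units; within the scatter), stayed within the scatter. In this assay the expected step is therefore small, a 1.8-fold higher number from compound 2 to compound 4 (0.26 log units; within the scatter), with no change beyond the scatter. Compound 4 is expected at 40 nM, between 15 nM and 120 nM.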

Compound 4, inhibition constant: 30 nM
Estimate against measurement, compound 4: 1.3-fold (0.12 log units) above; low and high end bracket the measured number.
By their numbers in this assay, from the lowest: compounds 2, 4 and 3 (each within the scatter of the next); then compound 1.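

In this assay, a third replacement for carboxy gives a large step, a 33-fold lower number from compound 1 to compound 4 (1.52 log units; beyond the scatter). Trifluoromethyl cannot be told apart from hydroxy, a 1.4-fold higher number from compound 2 to compound 4 (0.13 log units; within the scatter), or from chloro, a 1.2-fold lower number from compound 3 to compound 4 (0.07 log units; within the scatter), although it brings more heavy atoms than hydroxy and no hydrogen-bond donor, so a hydrogen-bond donor at this position is not required for numbers in this range. No available measurement explains this. Open, from the compounds shown here alone, is whether an amine or a methyl ester at this position would stay in this range, and what the remaining carboxy of the shared core contributes.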